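Chloro for fluoro on the anilino ring of compound 3

This account rests on a few compounds, and the source may have more. Where it says the series, first, only, none or still open, it means among the compounds named here.

Compound 3, `O=C(/C=C\Nc1ccc(F)cc1)c1cn(-c2ccccc2)nc1-c1ccc(Cl)cc1`, reaches only the limit of a functional assay on A549 cells (Homo sapiens) for antiproliferative activity, read by MTT assay, with a stated time of 48 h (a higher number here means a weaker inhibitor, a lower number a stronger inhibitor), giving > 50000 nM, which is a limit and not a number. The change to compound 4, `O=C(/C=C\Nc1ccc(Cl)cc1)c1cn(-c2ccccc2)nc1-c1ccc(Cl)cc1`, is chloro in place of fluoro on an aromatic carbon. Going by the values given here, no measured step covers this exact exchange. Among the compounds with values here, the only measured step in this assay, a 2.1-fold lower number from compound 1 to compound 2 (0.32 log units; beyond the scatter), concerns a different ring and a different pair of groups, and it was modest. Compound 1, `O=C(/C=C\Nc1ccc(Cl)cc1)c1cn(-c2ccccc2)nc1-c1ccccc1`, gives 14100 nM in this assay, and compound 2, `O=C(/C=C\Nc1ccc(Cl)cc1)c1cn(-c2ccccc2)nc1-c1ccc(F)cc1`, gives 6700 nM. Compound 2 and compound 4 share the chlorine on the anilino ring, and compound 2 sits at a measured number rather than at the limit, so compound 4 is expected to return a number below the limit as well, though the limit of the limit of > 50000 nM in this assay, at which 1 of the 3 values shown sits, leaves the size of the step from compound 3 uncertain. The step of an at least 5.0-fold lower number from compound 3 to compound 4 (0.69 log units; beyond the scatter) is therefore expected to be a lowering. Compound 4 is estimated at 10000 nM, within 3000 nM to 40000 nM.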

Compound 4, half-maximal inhibitory concentration: 3670 nM
The estimate for compound 4 lay 2.7-fold (0.44 log units) above the measured number; the measured number falls inside the stated range.
By their numbers in this assay, from the lowest: compounds 4 and 2 (each within the scatter of the next); then compound 1. At a limit, above all of these: compound 3.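

In this assay, the change from (4-fluorophenyl)amino to (4-chlorophenyl)amino gives an at least 13-fold lower number from compound 3 to compound 4 (1.13 log units; beyond the scatter), which shows that the halogen at this position decides whether a number can be read at all. The same exchange of fluoro for chloro on the other aromatic ring gives only a 1.8-fold lower number from compound 2 to compound 4 (0.26 log units; within the scatter), and chloro in place of hydrogen on that ring gives a 3.8-fold lower number from compound 1 to compound 4 (0.58 log units; beyond the scatter), so among these compounds the exchange counts for far more on the amino-linked ring. Compound 3 stands at a limit, so the first step is a bound and not an exact size: the limit of > 50000 nM in this assay, at which 1 of the 4 values shown sits.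

The compounds shown hold only fluoro and chloro at this position, so it remains open how hydrogen, bromo, methoxy or an amine there would compare. As far as these compounds go, whether a larger group on this carbon would go beyond compound 4 also remains open.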